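This account rests on a few compounds, and the source may have more. Where it says the series, first, only, none or still open, it means among the compounds named here.

Compound 1 `CC(C)C(C(N)=O)c1ccc(Cl)cc1` and compound 2 `CC(C)[C@H](C(=O)NCc1ccccc1)c1ccc(Cl)cc1` share the same core, a primary amide in the first and a benzyl amide in the second. In a functional assay on CHO cells for agonist activity at Free fatty acid receptor 2 (Homo sapiens), read by cAMP accumulation (a lower number here means a stronger inhibitor, a higher number a weaker inhibitor), compound 1 returns only a limit, > 100000 nM. In this assay compound 2 likewise returns only a limit, > 100000 nM. Compound 2 therefore stands at the limit of > 100000 nM in this assay, at which 2 of the 2 values shown sit, with no number of its own. Compound 3 `CC(C)[C@H](C(=O)Nc1ncns1)c1ccc(Cl)cc1` differs from compound 2 in one place: 1,2,4-thiadiazol-5-yl in place of benzyl on an amide-type nitrogen. For the measured compounds named here, no measured step of this kind exists here, so the expectation is an estimated step of an at least 100-fold lower number from compound 2 to compound 3 (2.00 log units; beyond the scatter), beyond the usual scatter, toward a lower number. Compound 3 is accordingly estimated at 1000 nM, with a range from 100 nM to 20000 nM.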

Compound 3, half-maximal inhibitory concentration: 2000 nM
For compound 3 the middle estimate is 2.0-fold (0.30 log units) below the measured one, within the range that was stated.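

On the amide-type nitrogen, 1,2,4-thiadiazol-5-yl in place of benzyl gives an at least 50-fold lower number from compound 2 to compound 3 (1.69 log units; beyond the scatter) in this assay. Compound 3 thus shows that a change at this one place can bring a measurable number, which the primary amide and benzyl amide did not give. The true size of the step remains unknown, since compound 2 has only a limit: the limit of > 100000 nM in this assay, at which 2 of the 3 values shown sit.

Going by these compounds, it remains open which part of 1,2,4-thiadiazol-5-yl carries the step, its nitrogens or its sulfur. A thiazol-2-yl or a phenyl group on the same nitrogen would help separate these.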